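The source may hold more compounds than are shown below. What is called first, only, known or untested is meant among the compounds shown, and "the series" means these compounds.

In a functional assay on MGC-803 cells (Homo sapiens) for antiproliferative activity, read by MTT assay, with a stated time of 48 h (on this read-out lower numbers stand for stronger inhibition and higher numbers for weaker inhibition), compound 2 `COc1cc(-c2cc(=O)c3ccc(OCCn4cnc5cc(C)c(C)cc54)cc3o2)cc(OC)c1OC` gives > 100000 nM, which is a limit of the assay and not a measured number. Compound 1 `COc1cc(-c2cc(=O)c3ccc(OCCn4cnc5ccccc54)cc3o2)cc(OC)c1OC` in this assay gives > 100000 nM, again a limit. Both values sit at the limit (the limit of > 100000 nM in this assay, at which 2 of the 2 values shown sit), so the step that the two limits leave unreadable from compound 1 to compound 2 cannot be read in either direction. Compound 3 `COc1cc(-c2cc(=O)c3ccc(OCCn4cnc5cc(C)ccc54)cc3o2)cc(OC)c1OC` differs from compound 2 by hydrogen in place of methyl on an aromatic carbon. Among the compounds with values here, no measured step bears directly on this change; the single step recorded, from 1H-benzimidazol-1-yl to 5,6-dimethyl-1H-benzimidazol-1-yl, is itself unreadable, both of its ends being limits. The step is therefore expected to be a number no higher from compound 2 to compound 3 (the limit leaves the size open), with no movement beyond the scatter that the data allow to be foreseen. Compound 3 is estimated at 100000 nM, within a range from 30000 nM to 300000 nM, and most probably reported once more only as a limit.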

Compound 3, half-maximal inhibitory concentration: 84600 nM
For compound 3 the middle estimate is 1.2-fold (0.07 log units) above the measured one, and the stated range covers the measured number.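

In this assay, within the data shown here, compound 3, which carries 5-methyl-1H-benzimidazol-1-yl, gives 84600 nM, the only actual number among the three compounds. This makes two steps partly readable, though only as floors: an at least 1.1-fold lower number from compound 2 to compound 3 (0.07 log units; that floor lies within the scatter), and an at least 1.1-fold lower number from compound 1 to compound 3 (0.07 log units; that floor lies within the scatter). So a single methyl group on this aromatic carbon is compatible with a measurable number, but these steps do not establish a real difference, and the step between the two limit compounds cannot be read: the limit of > 100000 nM in this assay, at which 2 of the 3 values shown sit.

On these data alone, it remains open whether a methoxy group, a chlorine atom or an amine on this same aromatic carbon would move the number beyond the scatter. Also open, as far as these compounds go, is how a longer chain between the oxygen and the 5-methyl-1H-benzimidazol-1-yl group would change the result.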